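A few compounds are considered here, and "the series" means these few. Any claim that something is new, unique, unknown or untested is made for them only; others in the source may bear on it.

Measured compounds:
compound 1 `CN1[C@@H]2c3[nH]c4ccccc4c3C[C@H]1[C@H](C#N)N1[C@@H](CN3C(=O)c4ccccc4C3=O)c3[nH]c4ccccc4c3C[C@@H]21`, in a functional assay on BGC-823 cells (Homo sapiens) for cytotoxicity, read by MTT assay, with a stated time of 72 h (a lower number here means a stronger inhibitor, a higher number a weaker inhibitor), compound 1 gives 410 nM
compound 2 `CN1[C@@H]2c3[nH]c4ccccc4c3C[C@H]1[C@H](C#N)N1[C@@H](CNC(=O)c3cccc(C(F)(F)F)c3)c3[nH]c4ccccc4c3C[C@@H]21`, compound 2 gives 870 nM
compound 3 `CN1[C@@H]2c3[nH]c4ccccc4c3C[C@H]1[C@H](C#N)N1[C@@H](CNC(=O)c3cccc4c3CCCC4)c3[nH]c4ccccc4c3C[C@@H]21`, compound 3 gives 3540 nM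

Compound 3 stands at the highest number of the three, its nearest neighbour being compound 2 and the furthest compound 1. Compound 4 `CN1[C@@H]2c3[nH]c4ccccc4c3C[C@H]1[C@H](C#N)N1[C@@H](CNC(=O)c3cc4ccccc4[nH]3)c3[nH]c4ccccc4c3C[C@@H]21` differs from compound 3 by 1H-indol-2-yl in place of 1,2,3,4-tetrahydronaphthalen-5-yl on a carbonyl carbon. Within the data shown here, the only measured step at this carbonyl carbon is a 4.1-fold higher number from compound 2 to compound 3 (0.61 log units; beyond the scatter), which shows that exchanging the group on the amide carbonyl can shift the number beyond the scatter. Among the measured compounds shown here, with only one such step to lean on, the direction for an indolyl group is not settled; a moderate move back toward compound 2 is expected, giving a 2.4-fold lower number from compound 3 to compound 4 (0.37 log units; beyond the scatter). For compound 4 in this assay the estimate is 1500 nM, with a range from 500 nM to 4500 nM.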

Compound 4, half-maximal inhibitory concentration: 1690 nM
Beside the measured number, compound 4's estimate is 1.1-fold (0.05 log units) below it; the range from low to high includes it.
By their numbers in this assay, from the lowest: compound 1; then compounds 2 and 4 (each within the scatter of the next); then compound 3.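

In this assay, the carbonyl position proves sensitive in both directions: 1H-indol-2-yl in place of 1,2,3,4-tetrahydronaphthalen-5-yl gives a 2.1-fold lower number from compound 3 to compound 4 (0.32 log units; beyond the scatter). Two different groups on this carbonyl carbon can also read alike, as 1H-indol-2-yl and 3-(trifluoromethyl)phenyl give a 1.9-fold higher number from compound 2 to compound 4 (0.29 log units; within the scatter), while the group on the saturated chain carbon of compound 1 remains apart, with a 4.1-fold higher number from compound 1 to compound 4 (0.62 log units; beyond the scatter). Nothing available explains these differences.

As far as these compounds go, it remains open whether the hydrogen on the indole nitrogen matters, which a 1-methyl-1H-indol-2-yl group would test. From the compounds shown here alone, how a butyl chain on this carbonyl carbon would read is also open.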